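Carbamoyl for Trifluoromethyl on a Weakly Cytotoxic Urea

The source may report more compounds than this note shows. Statements on the series, on what has been measured and on what is new or still open speak of the compounds shown alone.

Compound 1 `Cc1cc(NC(=O)Nc2ccccc2C(F)(F)F)c2ccccc2n1` was examined in an ADME assay on Raji cells (Homo sapiens) for cytotoxicity, with a stated time of 72 h; on this read-out higher numbers stand for an effect only at larger amounts of compound and lower numbers for an effect already at smaller amounts. Compound 1 reaches only the limit > 25000 nM, so no number is known for it. Two related ureas sit alongside it. Compound 2 `CSc1ccc(NC(=O)Nc2cc(C)nc3ccccc23)cc1` also gives only the limit > 25000 nM. Compound 3 `COC(=O)c1cccc(NC(=O)Nc2cc(C)nc3ccccc23)c1` gives 26000 nM, a measured number. Compound 1 thus stands where all three shown compounds stand, at the weak end of the read-out, as the limit of > 25000 nM in this assay, at which 2 of the 3 values shown sit, shows. Among the measured compounds shown here, no two measured compounds differ in a single place, so no measured step size is available for this series.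

Compound 4 `Cc1cc(NC(=O)Nc2ccccc2C(N)=O)c2ccccc2n1` differs from compound 1 in one place: carbamoyl in place of trifluoromethyl on an aromatic carbon. Compound 1 gives only the limit > 25000 nM in this assay, which leaves no numerical starting point from which a change could be measured downward. The expected step that the limit leaves unreadable from compound 1 to compound 4 is estimated to be none beyond the scatter, in either direction. Compound 4 is therefore expected to give about 30000 nM in this assay, with a plausible range from 15000 nM to 70000 nM, and it is likely that the read-out will again report only a limit.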

Compound 4, half-maximal effective concentration: > 25000 nM
Compound 4 ended at the assay's limit; the forecaster's own chance of this, stated with the estimate: 70%; the middle value lies beyond the limit too.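

Among the compounds shown here, compound 1 and compound 4 both stand only as limits in this assay and so no step between them can be read: the limit of > 25000 nM in this assay, at which 3 of the 4 values shown sit. The compounds shown leave open how large the change from trifluoromethyl to carbamoyl really is, and whether any change to the shared core would produce an effect at smaller amounts of compound.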